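Acid ceramidase series: piperidinyl in place of oxanyl

The compounds below may be only part of what the source reports. "The series", "measured", "known", "first", "only" and "open" are said of these compounds alone.

Measured compounds:
compound 1 `O=C(NCCCCc1ccccc1)n1c(=O)oc2cc(C3CCOCC3)ccc21` — 68 nM
compound 2 `CN1CCC(c2ccc3c(c2)oc(=O)n3C(=O)NCCOCc2ccccc2)CC1` — 215 nM
compound 3 `CC(C)CNC(=O)n1c(=O)oc2ccc(C3CCN(C)CC3)cc21` — 295 nM

In an assay on HEK293 cells for inhibition of acid ceramidase (Homo sapiens), read by fluorescence, with stated times of 10 min and 3 h (on this read-out lower numbers stand for stronger inhibition and higher numbers for weaker inhibition), compound 1 gives the lowest of the three numbers; compound 2 and compound 3 both lie beyond the scatter above it. Compound 4 `CC(C)CN1CCC(c2ccc3c(c2)oc(=O)n3C(=O)NCCCCc2ccccc2)CC1` has not yet been measured in this assay. It keeps the core and the amide chain of compound 1 and differs only at one place: 1-isobutylpiperidin-4-yl in place of oxan-4-yl on an aromatic carbon. For the measured compounds named here, no measured pair isolates this change, so its size is unknown. Compound 2 and compound 3 show that a basic ring of this kind is tolerated on the core, with chains other than that of compound 1. For compound 4 a step of a 1.4-fold higher number from compound 1 to compound 4 (0.15 log units; within the scatter) is expected, that is no change beyond the scatter, giving an estimated value of 95 nM with a range from 30 nM to 300 nM.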

Compound 4, half-maximal inhibitory concentration: 120 nM
Beside the measured number, compound 4's estimate is 1.3-fold (0.10 log units) below it, within the range that was stated.
By their numbers in this assay, from the lowest: compounds 1, 4, 2 and 3 (each within the scatter of the next, the first and the last beyond it).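

In this assay the first pair isolating this position gives a 1.8-fold higher number from compound 1 to compound 4 (0.25 log units; within the scatter) with the amide chain held constant. At this position on the shared core, the 10 heavy atoms of 1-isobutylpiperidin-4-yl therefore stand in place of the 6 of oxan-4-yl with no change beyond the scatter. Nothing available explains this tolerance.

Still open, as far as these compounds go, is how an unsubstituted piperidin-4-yl would compare on this amide chain. Also open, from the compounds shown here alone, is whether a longer chain or a carboxylic acid on the ring nitrogen would stay within the scatter.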